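Carboxy in Place of Nitrile: Following Compound 3 to Compound 4

The source may report more compounds than this note shows. Statements on the series, on what has been measured and on what is new or still open speak of the compounds shown alone.

Measured compounds:
compound 1 `Cc1n[nH]c(C(=O)O)c1Cc1ccccc1-c1ccc(F)cc1`: 56%
compound 2 `Cc1n[nH]c(C(=O)O)c1Cc1cccc(C(N)=O)c1`: 8%
compound 3 `Cc1n[nH]c(C(=O)O)c1Cc1ccc(C#N)cc1`: 6%

Three compounds that share one core were tested in an assay on isolated protein for inhibition of 2-Hydroxyacid oxidase 2 (Homo sapiens), tested at 10 uM; a lower number here means a weaker effect, a higher number a stronger effect of the compound at the concentration tested. Compound 1 gives 56%. Compound 2 gives 8%, and compound 3 gives 6%, the lowest of the three numbers. The gap from compound 3 to compound 2 lies within the scatter, so nothing separates these two; the gap to compound 1 is far beyond it.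

Compound 4 `Cc1n[nH]c(C(=O)O)c1Cc1ccc(C(=O)O)cc1` is not yet measured. It differs from compound 3 in one place: carboxy in place of cyano on an aromatic carbon. Within the data shown here, no comparable step between measured compounds exists here, so the size of the change is a guess. Compound 4 is expected to stay close to compound 3, with the step of a number 4 percentage points higher from compound 3 to compound 4 (within the scatter) at most within the scatter. The estimate for compound 4 in this assay is 10%, from 0% to 30%.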

Compound 4, a percentage reported as inhibition, at one concentration (the size of the read-out at that concentration, not a potency): 22%
Compound 4: the middle estimate sits 12 percentage points below what was measured; measured number inside the range.
By their numbers in this assay, from the lowest: compounds 3 and 2 (each within the scatter of the next); then compound 4; then compound 1.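

Among these compounds, at this position, para to a large group, the choice of group does change the read-out: in this assay, carboxy in place of cyano gives a number 16 percentage points higher from compound 3 to compound 4 (beyond the scatter) and so provides the first direct comparison, a modest one. No available evidence accounts for this step. As far as these compounds go, whether an amine or a methyl ester at the same position would move the number further remains open. So does whether carboxy would give a similar step elsewhere on this ring.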